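The source may report more compounds than this note shows. Statements on the series, on what has been measured and on what is new or still open speak of the compounds shown alone.

In an assay on isolated protein for inhibition of phosphodiesterase 4A (Sus scrofa) (a higher number here means a weaker inhibitor, a lower number a stronger inhibitor), three compounds built on a shared core have been measured. Compound 1 `COc1ccc(C(=O)Nc2ccccc2F)cc1OC1CCCC1` gives 10700 nM, the highest of the three numbers and therefore the weakest inhibitor of the set. Compound 3 `COc1ccc(C(=O)Nc2ccccc2Cl)cc1OC` gives 650 nM, and compound 2 `COc1ccc(C(=O)Nc2c(F)cccc2F)cc1OC1CCCCC1` gives 400 nM, both beyond the scatter from compound 1. Within the data shown here, compound 2 and compound 3 differ from compound 1 in more than one place, so no single step between them can be read off.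

Compound 4 `COc1ccc(C(=O)Nc2c(Br)cncc2Br)cc1OC1CCCC1` has not yet been measured. It differs from compound 1 in one place: 3,5-dibromopyridin-4-yl in place of 2-fluorophenyl on an amide-type nitrogen. Two bromine atoms on a pyridine ring replace a single fluorine on a phenyl ring, with the amide-type nitrogen unchanged.

Because compound 2, which carries two halogens on its ring, gives 400 nM while compound 1 gives 10700 nM, a step toward a lower number is expected for compound 4, well beyond the scatter. Compound 4 is therefore estimated at 80 nM, within a range from 8 nM to 800 nM, which is expected to mean a step of a 130-fold lower number from compound 1 to compound 4 (2.13 log units; beyond the scatter).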

Compound 4, half-maximal inhibitory concentration: 7 nM
The estimate for compound 4 lay 11-fold (1.06 log units) above the measured number; the whole stated range lies above it.
By their numbers in this assay, from the lowest: compound 4; then compounds 2 and 3 (each within the scatter of the next); then compound 1.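

With the rest of compound 1 unchanged, replacing only the group on the amide-type nitrogen moves the number in this assay by a very large amount, a 1500-fold lower number from compound 1 to compound 4 (3.18 log units; beyond the scatter). Among these compounds, this is the first comparison in the set that isolates a single place, and it shows that the potency of this series can depend strongly on the group held at this position, with 3,5-dibromopyridin-4-yl giving a far stronger inhibitor than 2-fluorophenyl. No measurement at hand explains the size of this step.

The change brings in the ring nitrogen and the two bromine atoms together, so this single step cannot show how much each contributes. A pyridine ring without bromine and a phenyl ring carrying two bromine atoms, each on this same core, would be needed to separate them.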